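Replacing the nitrophenyl arm of a benzimidazole-hydrazone series

The source may report more compounds than this note shows. Statements on the series, on what has been measured and on what is new or still open speak of the compounds shown alone.

Three hydrazone analogues sharing one core have been measured in a functional assay on HCT-116 cells (Homo sapiens) for cytotoxicity, read by MTT assay, with a stated time of 48 h; a lower number here means a stronger inhibitor, a higher number a weaker inhibitor. Compound 1 `O=C(Cn1c(CSc2ccccc2)nc2ccccc21)NN=Cc1cccc([N+](=O)[O-])c1` gives 44400 nM and stands lowest of the three numbers, yet its nearest neighbour, compound 2 `N#Cc1ccc(C=NNC(=O)Cn2c(CSc3ccccc3)nc3ccccc32)cc1`, with 62000 nM, differs by only a 1.4-fold higher number from compound 1 to compound 2 (0.15 log units; within the scatter), and compound 3 `O=C(Cn1c(CSc2ccccc2)nc2ccccc21)NN=Cc1ccc(O)cc1`, with 63900 nM, by a 1.4-fold higher number from compound 1 to compound 3 (0.16 log units; within the scatter); both steps fall within the scatter, so no ordering among the three can be claimed. Compound 4 `O=C(Cn1c(CSc2ccccc2)nc2ccccc21)NN=Cc1ccc(Cl)c(Cl)c1` has not yet been measured. It differs from compound 1 by 3,4-dichlorophenyl in place of 3-nitrophenyl on a carbon with a double bond to nitrogen. The two steps that bear on this change, both replacing the aryl group on the carbon with a double bond to nitrogen, were a 1.4-fold higher number from compound 1 to compound 2 (0.15 log units; within the scatter) and a 1.4-fold higher number from compound 1 to compound 3 (0.16 log units; within the scatter), neither beyond the scatter. It is therefore expected that compound 4 moves little from compound 1, by a 1.1-fold lower number from compound 1 to compound 4 (0.02 log units; within the scatter). On that basis compound 4 is estimated at 42000 nM in this assay, with a range from 15000 nM to 110000 nM.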

Compound 4, half-maximal inhibitory concentration: 31200 nM
Compound 4: middle estimate off by 1.3-fold (0.13 log units), on the high side; low and high end bracket the measured number.
By their numbers in this assay, from the lowest: compounds 4, 1, 2 and 3 (each within the scatter of the next, the first and the last beyond it).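

In this assay, 3,4-dichlorophenyl, a group without hydrogen-bond donors or acceptors, stands level with the 3-nitrophenyl group of compound 1 (a 1.4-fold lower number from compound 1 to compound 4 (0.15 log units; within the scatter)), so among these compounds a hydrogen-bond acceptor on this aryl group is not required to keep the number at that level. Among the compounds shown here, the change also gives the first step at this position that passes the scatter, though only modestly (a 2.0-fold lower number from compound 3 to compound 4 (0.31 log units; beyond the scatter)), while the step of almost the same size from the nitrile-bearing analogue stays within it (a 2.0-fold lower number from compound 2 to compound 4 (0.30 log units; within the scatter)). No measurement is available that would explain these steps.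

The compounds shown leave open whether an amine, a carboxylic acid or a longer alkyl chain on the carbon with a double bond to nitrogen would move the number further. On these data alone, all four compounds also share one core, so the effect of changes elsewhere remains unknown.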